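A few compounds are considered here, and "the series" means these few. Any claim that something is new, unique, unknown or untested is made for them only; others in the source may bear on it.

For the measured compounds named here, in an ADME assay on HEK293 cells (Homo sapiens) for cytotoxicity, read by MTT assay, with a stated time of 72 h (on this read-out lower numbers stand for stronger inhibition and higher numbers for weaker inhibition), compound 1 `COc1ccc(OC)c(C2=C(c3cc(OC)c(OC)c(OC)c3)C(=O)CC2O[SiH2]C(C)(C)C)c1` gives 9.5 ug/mL, the lowest of the two actual numbers measured so far. Compound 3 `CC(=O)OC1C/C(=N/O)C(c2ccccc2)=C1c1ccccc1` is the nearest, at 92.3 ug/mL, and this gap lies beyond the usual scatter of repeated measurements. Compound 2 `COc1ccc(C2=C(c3cc(OC)c(OC)c(OC)c3)CC(O)C2=O)cc1[N+](=O)[O-]` gives > 100 ug/mL, which is a limit of the assay and not a number.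

The next compound to be tested is compound 4 `COc1cc(C2=C(c3cc(C)c(OC)c(C)c3)C(O[SiH2]C(C)(C)C)CC2=O)cc(OC)c1OC`. It keeps the core of compound 1 but carries 4-methoxy-3,5-dimethylphenyl in place of 2,5-dimethoxyphenyl on a double-bonded ring carbon. Going by the values given here, no two measured compounds differ in just one place, so the data do not show what a swap of this kind does in this assay. The best starting point is therefore compound 1 at 9.5 ug/mL, the closest measured relative, and the expectation stays deliberately broad. The expected step of a 1.3-fold higher number from compound 1 to compound 4 (0.10 log units; within the scatter) is small, leaning slightly towards a higher number and probably not clearly beyond the scatter. For compound 4 the estimated value is 12 ug/mL, with an expected range from 3.5 ug/mL to 40 ug/mL.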

Compound 4, half-maximal inhibitory concentration: 29 ug/mL
Beside the measured number, compound 4's estimate is 2.4-fold (0.38 log units) below it, and the stated range covers the measured number.
By their numbers in this assay, from the lowest: compound 1; then compound 4; then compound 3. At a limit, above all of these: compound 2.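

For the compounds shown here, replacing 2,5-dimethoxyphenyl with 4-methoxy-3,5-dimethylphenyl on a double-bonded ring carbon gives, in this assay, a 3.1-fold higher number from compound 1 to compound 4 (0.48 log units; beyond the scatter), the first step that isolates a change at a single place. Higher numbers here mean weaker inhibition, so this position is not indifferent to the aryl group it carries: two groups with the same number of heavy atoms and the same kind of aromatic ring, differing in their mix of carbon and oxygen and in their hydrogen-bond acceptors, give results that lie apart beyond the scatter. Nothing shown here accounts for why the number rises.

This single swap alters the methoxy and methyl groups together, so it cannot show which of these alterations matters, or whether one alone would produce a step of similar size. It also leaves open how the same position would respond to a ring carrying an amine or a carboxylic acid, and whether such a change would move the number in the same direction.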